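The source may hold more compounds than are shown below. What is called first, only, known or untested is meant among the compounds shown, and "the series" means these compounds.

Measured in a functional assay on HCT-116 cells (Homo sapiens) for cytotoxicity, read by MTT assay, with a stated time of 72 h; a lower number here means a stronger inhibitor, a higher number a weaker inhibitor:
- Compound 1 `Nc1ccc(Nc2c(C(=O)NCc3ccc(F)cc3)nc(Br)c3cccnc23)cc1`: 10000 nM
- Compound 2 `N[C@H]1CC[C@H](Nc2c(C(=O)NCc3ccc(F)cc3)nc(Br)c3cccnc23)CC1`: 7000 nM
- Compound 3 `CNc1c(C(=O)NCc2ccc(F)cc2)nc(Br)c2cccnc12`: > 20000 nM

Compound 3 has no exact number in this assay, only a limit of the assay. Its true value could lie anywhere on the weak side of that limit, so any step starting from it is uncertain.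

Compound 4 `Cc1ccc(S(=O)(=O)Oc2c(C(=O)NCc3ccc(F)cc3)nc(Br)c3cccnc23)cc1` keeps the shared core, but ((4-methylphenyl)sulfonyl)oxy takes the place of methylamino on an aromatic carbon (((4-methylphenyl)sulfonyl)oxy in place of methylamino on an aromatic carbon). Among the measured compounds shown here, no measured compound has this group, so the guidance is indirect.

For the measured compounds named here, two measured steps bear on the change, as both exchange a larger ring-carrying group for a small methyl on the nitrogen. They are an at least 2.0-fold higher number from compound 1 to compound 3 (0.30 log units; that floor lies within the scatter) and an at least 2.8-fold higher number from compound 2 to compound 3 (0.45 log units; beyond the scatter). Read backwards, they suggest that adding a ring-carrying group may bring the number down modestly. The two ring-carrying groups themselves differ little, with a 1.4-fold lower number from compound 1 to compound 2 (0.15 log units; within the scatter).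

A modest move to a lower number is therefore expected, with the estimated step being an at least 2.0-fold lower number from compound 3 to compound 4 (0.30 log units; that floor lies within the scatter). For compound 4 the estimated value is 10000 nM, with an expected range of 3000 nM to 30000 nM.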

Compound 4, half-maximal inhibitory concentration: > 20000 nM
Compound 4: only a limit was reported; the forecaster's own chance of this, stated with the estimate: 30%; middle value at least 2.0-fold (0.30 log units) from the limit.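

In this assay compound 4 gives > 20000 nM, which is a limit of the assay and not a number. This shows that carrying a ring at this aromatic carbon is not enough on its own to give a measurable number, since only the amino-linked rings of compound 1 and compound 2 do so among the groups shown: the ((4-methylphenyl)sulfonyl)oxy group brings an at least 2.8-fold higher number from compound 2 to compound 4 (0.45 log units; beyond the scatter), and also an at least 2.0-fold higher number from compound 1 to compound 4 (0.30 log units; that floor lies within the scatter), so only the step from compound 2 is firmly beyond the scatter. The step between compound 3 and compound 4 cannot be read because both stand at the same limit: the limit of > 20000 nM in this assay, at which 2 of the 4 values shown sit.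

As far as these compounds go, what stays open is whether the oxygen link or the sulfonyl unit matters more, since compound 4 differs from compound 1 in both as well as in the ring's amino substituent. A phenoxy group, which would hold a ring on this carbon through oxygen with no sulfonyl, or a benzylamino group, which would keep the nitrogen link with a plain ring, could help separate these, and the compounds shown say nothing about either.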